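A few compounds are considered here, and "the series" means these few. Any claim that something is new, unique, unknown or untested is made for them only; others in the source may bear on it.

Compound 1 `CC1=C(C(=O)NC(C)C)C(c2ccco2)NC(=O)N1` and compound 2 `CC1=C(C(=O)NC(C)C)C(c2cccs2)NC(=O)N1` share the same core and were both tested in an assay on membranes from HeLa cells for displacement of a labelled ligand from adenosine receptor A3 (Homo sapiens), read by scintillation counting, with a stated time of 180 min, tested at 1 uM; a higher number here means more inhibition at the concentration tested (going by the name of the read-out), a lower number less inhibition. Compound 1 gives 4% in this assay, and compound 2 gives 1%. Compound 1 stands highest of the two numbers, but the step of a number 3 percentage points lower from compound 1 to compound 2 (within the scatter) is within the scatter, so the two compounds cannot be told apart on these data. Compound 3 `CC1=C(C(=O)OCC2CCC2)C(c2ccco2)NC(=O)N1` is not yet measured. It differs from compound 1 in a single place: cyclobutylmethoxy in place of isopropylamino on a carbonyl carbon. Going by the values given here, no measured step bears on this change: the only step available, a number 3 percentage points lower from compound 1 to compound 2 (within the scatter), concerns thiophen-2-yl in place of furan-2-yl on a saturated ring carbon and says nothing about the carbonyl carbon. With compound 1 already low, the most that can be said is that no step beyond the scatter is anticipated in either direction. The change is therefore expected to amount to a number 1 percentage points higher from compound 1 to compound 3 (within the scatter). Compound 3 is estimated to give about 5% in this assay, most likely between -5% and 15%.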

Compound 3, a percentage reported as inhibition, at one concentration (the size of the read-out at that concentration, not a potency): 1%
The estimate for compound 3 lay 4 percentage points above the measured number; the measured number falls inside the stated range.
By their numbers in this assay, from the lowest: compounds 2, 3 and 1 (each within the scatter of the next).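

In this assay, the carbonyl carbon now has a measured step of its own: with cyclobutylmethoxy in place of isopropylamino, the result is a number 3 percentage points lower from compound 1 to compound 3 (within the scatter). Even this exchange, which removes the hydrogen-bond donor of isopropylamino and brings in a four-membered ring, does not separate the two compounds, so this position shows no measurable response to this change on these data. Nothing available explains why the read-out stays where it does.

As far as these compounds go, it remains open whether any group on this carbonyl carbon can move the number beyond the scatter, for example a carboxylic acid, a benzylamino group or a longer alkoxy chain. From the compounds shown here alone, it is also open whether the thiophen-2-yl group would behave any differently alongside cyclobutylmethoxy.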